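Shifting a Methyl Group on Two Related Cores

The compounds below may be only part of what the source reports. "The series", "measured", "known", "first", "only" and "open" are said of these compounds alone.

Compound 1 `Cc1cccc(-n2cc(-c3cccc(NS(=O)(=O)c4c[nH]c(=O)[nH]c4=O)c3)nn2)c1` gives 4080 nM in a functional assay on OVCAR-3 cells (Homo sapiens) for antiproliferative activity, read by MTT assay, with a stated time of 24 h; a lower number here means a stronger inhibitor, a higher number a weaker inhibitor.
Compound 2 `Cc1ccc(-n2cc(-c3cccc(NS(=O)(=O)c4c[nH]c(=O)[nH]c4=O)c3)nn2)cc1` gives 3540 nM in this assay.
Compound 3 `Cc1cccc(-n2cc(-c3ccc(NS(=O)(=O)c4c[nH]c(=O)[nH]c4=O)cc3)nn2)c1` gives 7490 nM in this assay.

Compounds 1 and 2 share one core and differ only in the group on an aromatic nitrogen: 4-methylphenyl in place of 3-methylphenyl on an aromatic nitrogen. That change gave a 1.2-fold lower number from compound 1 to compound 2 (0.06 log units; within the scatter). Compound 3 has a different core; how its core differs from that of compound 1 is not broken down here. Compound 4 `Cc1ccc(-n2cc(-c3ccc(NS(=O)(=O)c4c[nH]c(=O)[nH]c4=O)cc3)nn2)cc1` is not yet measured. It stands to compound 3 as compound 2 stands to compound 1, through the same change, (4-methylphenyl in place of 3-methylphenyl on an aromatic nitrogen). The expectation rests on compound 1 and compound 2, whose change gave a 1.2-fold lower number from compound 1 to compound 2 (0.06 log units; within the scatter). A step of that size is expected again, a 1.2-fold lower number from compound 3 to compound 4 (0.08 log units; within the scatter). For compound 4 the estimate is 6300 nM, expected to fall between 3500 nM and 11500 nM in this assay.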

Compound 4, half-maximal inhibitory concentration: 5630 nM
Estimate against measurement, compound 4: 1.1-fold (0.05 log units) above; measured number inside the range.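

Putting 4-methylphenyl in place of 3-methylphenyl gave a 1.3-fold lower number from compound 3 to compound 4 (0.12 log units; within the scatter) in this assay on the second core, and this agrees with the same change on the core of compound 1: the same change on two cores in this assay, a 1.2-fold lower number (0.06 log units; within the scatter) from compound 1 to compound 2 and a 1.3-fold lower number (0.12 log units; within the scatter) from compound 3 to compound 4, 1.2-fold (0.06 log units) apart, within the scatter of two such steps.
So the change carries from one core to the other here in the sense that it stays small on both. Since neither step lies beyond the scatter, this does not show a real preference for either methyl placement, nor that a third core would behave alike.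

The compounds shown leave open what a different group on that aromatic nitrogen would do, such as a phenyl bearing an amine or a carboxylic acid. They also leave open whether a longer chain in place of the methyl would carry across the two cores in the same way.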